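This account rests on a few compounds, and the source may have more. Where it says the series, first, only, none or still open, it means among the compounds named here.

Measured compounds:
Compound 1, `COc1cc2oc(-c3cccc(NC(=O)c4ccc(Cl)cc4)c3)cc(=O)c2c(OC)c1OC`, gives 51.1% in a functional assay on UO-31 cells (Homo sapiens) for inhibition, read by sulforhodamine B assay, tested at 10 uM; a lower number here means less inhibition, a higher number more inhibition at the concentration tested (going by the name of the read-out).
Compound 2, `COc1cc2oc(-c3cccc(NC(=O)c4ccc([N+](=O)[O-])cc4)c3)cc(=O)c2c(OC)c1OC`, gives "active" (no number reported) in this assay.
Compound 3, `COc1cc2oc(-c3ccc(NC(=O)c4ccc(C)cc4)cc3)cc(=O)c2c(OC)c1OC`, gives "active" (no number reported) in this assay.

Compound 3 is reported as active in this assay, but no number accompanies that entry, and the same holds for compound 2. Only compound 1 carries a figure, 51.1%. Compound 3 therefore has no number that would let it be placed beside compound 1, so its relation to compound 1 cannot be read as a step of any size.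

Compound 4, `COc1cc2oc(-c3ccc(NC(=O)c4ccc(C(F)(F)F)cc4)cc3)cc(=O)c2c(OC)c1OC`, is the next compound to be tested. It differs from compound 3 in one place: trifluoromethyl in place of methyl on an aromatic carbon. Within the data shown here, no measured pair in this set shows such a change, so no size or direction of step can be drawn from the numbers; compound 1 offers the only numerical anchor for what the shared core gives in this assay at this concentration. For compound 4 the estimate is a value in this assay of about 50%, expected to lie between 25% and 75%.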

Compound 4, a percentage reported as inhibition, at one concentration (the size of the read-out at that concentration, not a potency): "active" (no number reported)
Compound 4 has no reported number here, and the estimate cannot be compared.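

Compound 3 and compound 4 are both reported as active without a number, so no step can be read between them in this assay. The compounds shown leave open how much inhibition either gives and whether trifluoromethyl in place of methyl changes it. No further data bear on this result.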